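Propoxycarbonyl to benzyloxycarbonyl on a shared pyrazoline core

The source may report more compounds than this note shows. Statements on the series, on what has been measured and on what is new or still open speak of the compounds shown alone.

Compound 1, `CCCOC(=O)N1N=C(c2ccc(OC)cc2)CC1c1cc(OC)c(OC)c(OC)c1`, gives > 10000 nM in a functional assay on A549 cells (Homo sapiens) for antiproliferative activity, read by MTT assay, with a stated time of 48 h (a lower number here means a stronger inhibitor of growth, a higher number a weaker inhibitor of growth), a limit and not a number.
Compound 2, `COc1ccc(C2=NN(C(=O)OCc3ccccc3)C(c3cc(OC)c(OC)c(OC)c3)C2)cc1`, gives > 10000 nM in this assay, again a limit.
Compound 3, `CCCOC(=O)N1N=C(c2cccc(O)c2)CC1c1cc(OC)c(OC)c(OC)c1`, gives > 10000 nM in this assay, also a limit.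

The change from compound 1 to compound 2 is phenyl in place of ethyl on a saturated chain carbon bound to an oxygen next to a carbonyl group, and the step it made, a step that the two limits leave unreadable from compound 1 to compound 2, cannot be sized because of the limit of > 10000 nM in this assay, at which 3 of the 3 values shown sit. The two cores differ by 3-hydroxyphenyl in place of 4-methoxyphenyl on a carbon with a double bond to nitrogen, with a step that the two limits leave unreadable from compound 1 to compound 3 likewise unreadable. Compound 4, `COc1cc(C2CC(c3cccc(O)c3)=NN2C(=O)OCc2ccccc2)cc(OC)c1OC`, carries the same change, (phenyl in place of ethyl on a saturated chain carbon bound to an oxygen next to a carbonyl group), at a place described in the same words. With every measured value sitting at the same limit, compound 4 is expected to show a step that the limit leaves unreadable from compound 3 to compound 4, since compound 3 gives only > 10000 nM. The estimate for compound 4 is 20000 nM, between 8000 nM and 60000 nM.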

Compound 4, concentration for 50% growth inhibition: > 10000 nM
Compound 4: a limit, no number; the forecaster's own chance of this, stated with the estimate: 80%; the middle value lies beyond the limit too.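

In this assay compound 4 gives > 10000 nM, a limit and not a number. No step to it from compound 2 or compound 3 can be read: the limit of > 10000 nM in this assay, at which 4 of the 4 values shown sit.

The compounds shown leave open how strongly any of them inhibits growth, and whether either change has any effect.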